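A few compounds are considered here, and "the series" means these few. Any claim that something is new, unique, unknown or untested is made for them only; others in the source may bear on it.

The series shares the core of compound 1 `Cc1ccc(CS/C(=C/c2ccc(F)c(C)c2)C(=O)c2ccc(Cl)cc2)cc1`. Compound 2 `CSc1ccc(/C=C(/SCc2ccc(C)cc2)C(=O)c2ccc(Cl)cc2)cc1` carries a 4-(methylsulfanyl)phenyl in place of 4-fluoro-3-methylphenyl on a double-bonded chain carbon bound to a double-bonded chain carbon. In a functional assay on DU-145 cells (Homo sapiens) for inhibition, read by trypan blue exclusion, with a stated time of 96 h (on this read-out lower numbers stand for stronger inhibition of growth and higher numbers for weaker inhibition of growth), compound 1 gives 25000 nM, and compound 2 gives 25000 nM. Compound 2 thus stands level with compound 1 at the digits given, as the step of no change at the digits printed from compound 1 to compound 2 (within the scatter) confirms. Compound 3 `CSc1ccc(/C=C(/SCc2ccc(C)cc2)C(=O)c2ccc(Br)cc2)cc1` has bromo in place of chloro on an aromatic carbon. In this assay compound 3 reaches only a limit of the assay, > 100000 nM. That step, an at least 4.0-fold higher number from compound 2 to compound 3 (0.60 log units; beyond the scatter), is the only one beyond the scatter, and the limit of > 100000 nM in this assay, at which 1 of the 3 values shown sits, is where its value sits. Compound 4 `Cc1ccc(CS/C(=C/c2cc([N+](=O)[O-])ccc2F)C(=O)c2ccc(Cl)cc2)cc1` differs from compound 2 by 2-fluoro-5-nitrophenyl in place of 4-(methylsulfanyl)phenyl on a double-bonded chain carbon bound to a double-bonded chain carbon. Among the compounds with values here, the one earlier exchange of the aryl group at this place is no change at the digits printed from compound 1 to compound 2 (within the scatter), and because no change at the digits printed from compound 1 to compound 2 (within the scatter) moved nothing, compound 4 is expected to show no change at the digits printed from compound 2 to compound 4 (within the scatter). Compound 4 is therefore estimated in this assay at 25000 nM, between 10000 nM and 100000 nM.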

Compound 4, concentration for 50% growth inhibition: 1000 nM
Estimate against measurement, compound 4: 25-fold (1.40 log units) above, and the stated range ends above it.
By their numbers in this assay, from the lowest: compound 4; then compounds 1 and 2 (each within the scatter of the next). At a limit, above all of these: compound 3.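

In this assay, the aryl group on a double-bonded chain carbon bound to a double-bonded chain carbon turns out to matter a great deal, with a 25-fold lower number from compound 2 to compound 4 (1.40 log units; beyond the scatter) and, matching it, a 25-fold lower number from compound 1 to compound 4 (1.40 log units; beyond the scatter). The earlier exchange at this place, no change at the digits printed from compound 1 to compound 2 (within the scatter), had moved nothing, so this position is not indifferent to its aryl group, and the 2-fluoro-5-nitrophenyl group sets compound 4 clearly apart from compounds 1 and 2. Nothing measured here accounts for this gain.

The compounds shown do not separate the nitro group from the fluoro group, so a phenyl carrying only one of them, or an amino group or a nitrile in place of the nitro group, would be needed to tell which one carries the step. Also open, on these data alone, is whether the step survives bromo in place of chloro on the aromatic carbon.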